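The source may report more compounds than this note shows. Statements on the series, on what has been measured and on what is new or still open speak of the compounds shown alone.

Measured compounds and their values:

Compound 1 `Nc1cc(N)c2nc(-c3ccccc3)c(Oc3ccc(Cl)c(Cl)c3)nc2c1`: 16200 nM
Compound 2 `CCOC(=O)[C@H](CCC(=O)O)NC(=O)c1ccc(CNc2nc3cc(N)cc(N)c3nc2-c2ccccc2)cc1`: < 100000 nM
Compound 3 `CCOC(=O)[C@H](CCC(=O)O)NC(=O)c1ccc(Sc2nc3cc(N)cc(N)c3nc2-c2ccccc2)cc1`: 3020 nM

In a functional assay on LOX IMVI cells (Homo sapiens) for inhibition, read by sulforhodamine B assay, with a stated time of 48 h (a higher number here means a weaker inhibitor of growth, a lower number a stronger inhibitor of growth), compound 1 gives 16200 nM, which is the higher of the two plain numbers recorded; compound 3 sits at 3020 nM, a gap that lies beyond the usual scatter. Compound 2 is reported only as a limit of this assay, (the limit of < 100000 nM in this assay, at which 1 of the 3 values shown sits), and its value of < 100000 nM is therefore not a number to be ranked against the others.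

Compound 4 `Nc1cc(N)c2nc(-c3ccccc3)c(NCc3ccc(F)cc3)nc2c1` has not yet been measured. It differs from compound 1 in one place: (4-fluorobenzyl)amino in place of 3,4-dichlorophenoxy on an aromatic carbon. The change puts a (4-fluorobenzyl)amino group where the 3,4-dichlorophenoxy group stood, on the aromatic carbon next to the ring nitrogen and ortho to the phenyl group of the shared core. Going by the values given here, no measured step of this kind exists among the three compounds, so the size of the step cannot be read from the data.

Compound 4 is expected to lie close to compound 1, with a step of a 1.2-fold higher number from compound 1 to compound 4 (0.09 log units; within the scatter) that would not clearly exceed the scatter. The estimate for compound 4 in this assay is 20000 nM, with a range from 5000 nM to 80000 nM.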

Compound 4, concentration for 50% growth inhibition: 1510 nM
Beside the measured number, compound 4's estimate is 13-fold (1.12 log units) above it; measured number below the stated range.
By their numbers in this assay, from the lowest: compounds 4 and 3 (each within the scatter of the next); then compound 1.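

In this assay, going by these compounds alone, the change of 3,4-dichlorophenoxy to (4-fluorobenzyl)amino on the aromatic carbon next to the ring nitrogen gives an 11-fold lower number from compound 1 to compound 4 (1.03 log units; beyond the scatter), the first step that can be read at a single place. It shows that the number at this position depends strongly on the group it carries, even though the leaving and entering groups each hold one six-membered aromatic ring of carbon only and neither has a net charge. The entering group has a hydrogen-bond donor that the leaving group lacks, but no measurement shown explains the size of the step.

The compounds shown do not separate the contributions of the amine nitrogen, the added methylene and the exchange of the two chlorines for fluorine, which 4-fluorophenoxy, unsubstituted benzylamino or 3,4-dichlorobenzylamino at this place could begin to tell apart. Also open, as far as these compounds go, is whether the same change would have a similar effect with a different group in place of the phenyl group on the shared core, such as a pyridyl or a methyl group.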